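The compounds below may be only part of what the source reports. "The series", "measured", "known", "first", "only" and "open" are said of these compounds alone.

Measured compounds:
- compound 1, `NC(=O)c1c(NC(=O)c2ccccc2Br)sc2c1CCN(C(=S)Nc1ccccc1Br)C2`: 17600 nM
- compound 2, `NC(=O)c1c(NC(=O)c2ccccc2I)sc2c1CCN(C(=S)Nc1ccccc1Br)C2`: 18900 nM

For the measured compounds named here, in a functional assay on HL-60 cells (Homo sapiens) for antiproliferative activity, with a stated time of 24 h (a lower number here means a stronger inhibitor, a higher number a weaker inhibitor), compound 1 gives 17600 nM, and compound 2 gives 18900 nM; the single measured step, a 1.1-fold higher number from compound 1 to compound 2 (0.03 log units; within the scatter), sits within the scatter, so the two compounds cannot be ordered on these numbers. Compound 2 thus stands level with compound 1 in this assay.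

Compound 3, `COc1ccccc1NC(=S)N1CCc2c(sc(NC(=O)c3ccccc3I)c2C(N)=O)C1`, is not yet measured. It differs from compound 2 by methoxy in place of bromo on an aromatic carbon. Going by the values given here, no measured step concerns this position or this exchange; the only step available, a 1.1-fold higher number from compound 1 to compound 2 (0.03 log units; within the scatter), is a halogen exchange on the other six-membered aromatic ring and was within the scatter. Nothing therefore points to a change beyond the scatter, and the expected step of a 1.1-fold higher number from compound 2 to compound 3 (0.02 log units; within the scatter) is set near zero with a wide range. Compound 3 is estimated at 20000 nM, expected between 7000 nM and 55000 nM in this assay.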

Compound 3, half-maximal inhibitory concentration: > 50000 nM
Compound 3: a limit, no number; the forecaster's own chance of this, stated with the estimate: 10%; at least 2.5-fold (0.39 log units) between middle value and limit.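

In this assay, methoxy in place of bromo on this aromatic carbon, ortho to a large group, gives an at least 2.6-fold higher number from compound 2 to compound 3 (0.42 log units; beyond the scatter), so this position responds to an exchange in a way that the halogen exchange on the other ring, a 1.1-fold higher number from compound 1 to compound 2 (0.03 log units; within the scatter), did not show. Compound 3 gives > 50000 nM, which is a limit of the assay and not a number. The step therefore has only a lower bound, and its full size stays unknown: the limit of > 50000 nM in this assay, at which 1 of the 3 values shown sits.

Open, on these data alone, is whether fluoro, methyl or an amine on this aromatic carbon would stay level with compound 2 or also give a weaker result. Also open, as far as these compounds go, is whether methoxy here has the same outcome with bromo in place of iodo on the other ring, as in compound 1.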